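The source may hold more compounds than are shown below. What is called first, only, known or untested is meant among the compounds shown, and "the series" means these compounds.

Of the compounds shown here, three sharing one core have been measured in a functional assay on HepG2 cells (Homo sapiens) for antiproliferative activity, read by MTT assay, with a stated time of 48 h; a lower number here means a stronger inhibitor, a higher number a weaker inhibitor. Compound 1 `COc1ccc(/C=C/c2cc(OC)cc(OC)c2/C=C/C(=O)c2ccc(Cl)c(Cl)c2)cc1` gives 10.8 ug/mL, compound 2 `CCCCCCOc1ccc(C(=O)/C=C/c2c(/C=C/c3ccc(OC)cc3)cc(OC)cc2OC)cc1` gives 16.2 ug/mL, and compound 3 `COc1ccc(/C=C/c2cc(OC)cc(OC)c2/C=C/C(=O)c2ccc(Cl)cc2)cc1` gives 13.6 ug/mL. Compound 3 therefore stands within the scatter of both other compounds.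

The next compound, compound 4 `COc1ccc(/C=C/c2cc(OC)cc(OC)c2/C=C/C(=O)c2ccccc2)cc1`, differs from compound 3 in one place: hydrogen in place of chloro on an aromatic carbon. This is hydrogen in place of chloro on an aromatic carbon, para to a large group. One measured step is the same kind of change, hydrogen in place of chloro, and it amounts to a 1.3-fold higher number from compound 1 to compound 3 (0.10 log units; within the scatter). A second step, chloro in place of hexyloxy, amounts to a 1.2-fold lower number from compound 2 to compound 3 (0.08 log units; within the scatter). Neither step points to a change beyond the scatter in this assay, and neither gives a firm direction. The expected step is a 1.1-fold higher number from compound 3 to compound 4 (0.04 log units; within the scatter), which would be no real shift. For compound 4 the estimated value is 15 ug/mL, with an expected range from 8 ug/mL to 28 ug/mL.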

Compound 4, half-maximal inhibitory concentration: 6.8 ug/mL
For compound 4 the middle estimate is 2.2-fold (0.34 log units) above the measured one, outside the stated range (below it).
By their numbers in this assay, from the lowest: compounds 4, 1, 3 and 2 (each within the scatter of the next, the first and the last beyond it).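

In this assay, the chloro group at this position proves dispensable, since hydrogen in its place gives a 2.0-fold lower number from compound 3 to compound 4 (0.30 log units; within the scatter), and phenyl in place of 3,4-dichlorophenyl gives a 1.6-fold lower number from compound 1 to compound 4 (0.20 log units; within the scatter). Only the replacement of hexyloxy by hydrogen clears the scatter, with a 2.4-fold lower number from compound 2 to compound 4 (0.38 log units; beyond the scatter), a modest step. The earlier compounds shown here could not separate any two groups at this position, whereas hexyloxy and hydrogen now stand apart, though the chloro compounds cannot be separated from either neighbour in this way. Nothing available explains these numbers. On these data alone, what an amine, a carboxylic acid or a shorter chain such as ethoxy would do at this position remains open, and so does whether any group here can go clearly beyond the plain phenyl of compound 4.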